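A Side-Group Exchange Starting From Compound 2

The source may report more compounds than this note shows. Statements on the series, on what has been measured and on what is new or still open speak of the compounds shown alone.

In a functional assay on KMS-11 cells (Homo sapiens) for antiproliferative activity, read by CellTiter-Glo, with a stated time of 72 h (a higher number here means a weaker inhibitor, a lower number a stronger inhibitor), compound 1 (`COc1ccc(C(=O)N(Cc2ccncc2)Cc2cccc(OCCc3ccccc3)c2)cc1`) gives 16900 nM, compound 2 (`COc1ccc(C(=O)N(Cc2ccncc2)Cc2cccc(OCc3ccc([N+](=O)[O-])cc3)c2)cc1`) gives 15400 nM and compound 3 (`O=C(c1ccc(Cl)cc1)N(Cc1ccncc1)Cc1cccc(OCCc2ccc(F)cc2)c1`) gives 13100 nM. Compound 2 therefore stands within the usual scatter of both other compounds, and the numbers set it apart from neither.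

Compound 4 (`COc1ccc(C(=O)N(Cc2ccncc2)Cc2cccc(OCC(=O)c3cccc(Br)c3)c2)cc1`) carries (3-bromophenyl)carbonyl in place of 4-nitrophenyl on a saturated chain carbon bound to an oxygen on an aromatic ring.

Among the measured compounds shown here, one measured step bears on this place. Putting 4-nitrophenyl in place of benzyl gave a 1.1-fold lower number from compound 1 to compound 2 (0.04 log units; within the scatter), a change that stays within the scatter. For the measured compounds named here, no measured compound carries the entering group, so this single step is a thin guide. Even so, the quiet result at this place gives no reason to expect a real shift in either direction in this assay.

The expected change is a 1.1-fold lower number from compound 2 to compound 4 (0.04 log units; within the scatter), which would be no step beyond the scatter. Compound 4 is estimated at 14000 nM, with an expected range of 6000 nM to 30000 nM.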

Compound 4, half-maximal inhibitory concentration: 18700 nM
Beside the measured number, compound 4's estimate is 1.3-fold (0.13 log units) below it, and the stated range covers the measured number.
By their numbers in this assay, from the lowest: compounds 3, 2, 1 and 4 (each within the scatter of the next).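

Putting (3-bromophenyl)carbonyl in place of 4-nitrophenyl gives a 1.2-fold higher number from compound 2 to compound 4 (0.08 log units; within the scatter), and putting it in place of benzyl gives a 1.1-fold higher number from compound 1 to compound 4 (0.04 log units; within the scatter). The earlier step compared only benzyl and 4-nitrophenyl; this result adds a third group, one that brings a carbonyl and a bromine, and the numbers for all three on this saturated chain carbon still cannot be told apart. No measurement here explains why these different groups read alike.

The compounds shown leave open whether an amine or a carboxylic acid at this place would give a step beyond the scatter. They also leave open whether a longer chain between the oxygen and the outer ring would do so.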